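This account rests on a few compounds, and the source may have more. Where it says the series, first, only, none or still open, it means among the compounds named here.

Measured so far:
Compound 1 `C=C1CC[C@H]2C(C)(C)CCC[C@]2(C)[C@H]1CC/C(C)=C/COc1c(-c2ccc(O)cc2)oc2cc(O)cc(O)c2c1=O`: 26000 nM
Compound 2 `C=C1CC[C@H]2C(C)(C)CCC[C@]2(C)[C@H]1CC/C(C)=C/COc1cc(O)c2c(=O)c(O)c(-c3ccc(O)cc3)oc2c1`: > 100000 nM, a limit of the assay

Among the measured compounds shown here, in a functional assay on A549 cells (Homo sapiens) for cytotoxicity, read by XTT assay, with a stated time of 72 h (a lower number here means a stronger inhibitor, a higher number a weaker inhibitor), compound 1 holds the only actual number, 26000 nM. Compound 2 is reported only as a limit, > 100000 nM. Compound 3 `C=C1CC[C@H]2C(C)(C)CCC[C@]2(C)[C@H]1CC/C(C)=C/COc1c(-c2ccc(OC)cc2)oc2cc(O)cc(O)c2c1=O` keeps the core of compound 1 and changes one group, 4-hydroxyphenyl to 4-methoxyphenyl: methyl in place of hydrogen on an oxygen on an aromatic ring. For the measured compounds named here, no measured pair shows this change. A small shift toward weaker inhibition in this assay is expected, possibly none beyond the scatter. The estimated step is a 1.2-fold higher number from compound 1 to compound 3 (0.09 log units; within the scatter). For compound 3 the expected value is 32000 nM, with an estimated range from 13000 nM to 85000 nM.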

Compound 3, half-maximal inhibitory concentration: 30000 nM
For compound 3 the middle estimate is 1.1-fold (0.03 log units) above the measured one; the measured number falls inside the stated range.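

In this assay, methyl in place of hydrogen on this oxygen gives a 1.2-fold higher number from compound 1 to compound 3 (0.06 log units; within the scatter) and so stays within the scatter. The free hydroxy of the 4-hydroxyphenyl group is thus not required to keep the number of compound 1, and 4-methoxyphenyl serves equally well here. Nothing available accounts for this result. The compounds shown leave open whether a longer chain on this oxygen, or an amine in place of the hydroxy, would also keep the number. They also leave open whether the hydroxy groups on the shared core accept methyl in the same way.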